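A few compounds are considered here, and "the series" means these few. Any claim that something is new, unique, unknown or untested is made for them only; others in the source may bear on it.

Measured compounds:
- compound 1, `CCN(c1cccc(-c2ccccc2)c1)c1ccc(C#N)c(Cl)c1`: "not determined" (no result reported)
- compound 2, `N#Cc1ccc(N2CCCc3c(-c4cccnc4)cccc32)cc1C(F)(F)F`: 7970 nM
- compound 3, `CCN(c1ccc(C#N)c(Cl)c1)c1cc(-c2ccccc2)ccc1C`: "not determined" (no result reported)

Compound 3 has no single number to stand on: its own result was not reported, and the same is true of compound 1, so no comparison between these two can be drawn. For the measured compounds named here, the only number available comes from compound 2, which in a functional assay on PC-3 cells (Homo sapiens) for antiproliferative activity, read by CCK-8 assay, with a stated time of 6 days (a lower number here means a stronger inhibitor, a higher number a weaker inhibitor), gives 7970 nM. Compound 2 shares the nitrile group and a pyridin-3-yl with the unmeasured compound but is built on a different, fused core, so its value is a rough anchor rather than a direct guide.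

Compound 4, `CCN(c1ccc(C#N)c(Cl)c1)c1cc(-c2cccnc2)ccc1C`, differs from compound 3 in one place: pyridin-3-yl in place of phenyl on an aromatic carbon

Going by the values given here, since no step between measured compounds is known, only a modest change in this assay is expected from this swap, in either direction, and most likely none beyond the usual scatter. Compound 4 is therefore estimated to reach about 6000 nM, with a plausible range from 1200 nM to 30000 nM.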

Compound 4, half-maximal inhibitory concentration: 11000 nM
Compound 4: middle estimate off by 1.8-fold (0.26 log units), on the low side, within the range that was stated.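

In this assay compound 3 reads "not determined" (no result reported) while compound 4 gives 11000 nM as its value, so no step can be read between these two compounds. Going by these compounds, whether pyridin-3-yl in place of phenyl shifts activity on this scaffold stays open. No further data bear on this result.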